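A few compounds are considered here, and "the series" means these few. Any claim that something is new, unique, unknown or untested is made for them only; others in the source may bear on it.

Measured so far:
- compound 1 `CCC(=O)c1c(-c2ccccc2)c2cc(Cl)ccc2c(=O)n1Cc1cc(C(N)=O)n(CC)n1`: 4.08 in a physicochemical assay for lipophilicity, at pH 7.4; a higher number here means a more lipophilic compound, a lower number a more polar compound
- compound 2 `CCC(=O)c1c(-c2ccccc2)c2cc(Cl)ccc2c(=O)n1Cc1cn(C(=O)NC)c(C)n1`: "not determined" (no result reported) in this assay

Compound 2 stands without a number in this assay; the only measured point in the series is compound 1, which gives 4.08 in this assay. Nothing can be said about where compound 2 sits relative to compound 1 on the shown numbers.

The step under consideration goes from compound 2 to compound 3 `CCNC(=O)n1cc(Cn2c(C(=O)CC)c(-c3ccccc3)c3cc(Cl)ccc3c2=O)cn1`. The change is 1-(ethylcarbamoyl)-1H-pyrazol-4-yl in place of 2-methyl-1-(methylcarbamoyl)-1H-imidazol-4-yl on a saturated chain carbon bound to an aromatic nitrogen. The two compounds hold the same atoms joined differently; the rearranged portion keeps the same count of donors and acceptors, so on paper the shift is small. The expectation for this assay is a step of modest size, in either direction, likely within the scatter of repeat measurements rather than beyond it.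

With compound 2 unmeasured, the estimate for compound 3 rests on compound 1 and its value of 4.08 in this assay, since the two share the core and carry a pyrazole bearing an ethyl-containing substituent. Compound 3 is therefore expected to give about 4 in this assay, with a range from 3.5 to 4.5.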

Compound 3, distribution coefficient: 4.45
The estimate for compound 3 lay 0.45 log units below the measured number, within the range that was stated.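

In this assay, going by these compounds alone, there is now a first readable step at this position, on a saturated chain carbon bound to an aromatic nitrogen: a number 0.37 log units higher from compound 1 to compound 3 (beyond the scatter) on placing 1-(ethylcarbamoyl)-1H-pyrazol-4-yl where 5-carbamoyl-1-ethyl-1H-pyrazol-3-yl stood. Both groups are substituted pyrazolyl groups, so a change confined to the substitution and attachment of that one ring type is enough to move this read-out beyond the scatter. Steps involving compound 2 cannot be read, as it carries no number, and no supporting data on hand account for the step that can be read.

As far as these compounds go, whether the higher number goes with the ethyl now sitting on the amide nitrogen or with the different attachment on the pyrazole stays open, as the two differ together in this one pair. Also open, from the compounds shown here alone, are where 2-methyl-1-(methylcarbamoyl)-1H-imidazol-4-yl stands on this scale and how a longer chain such as propylcarbamoyl, or a carboxylic acid in place of the carboxamide, would read in this assay at this position.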